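Carbamoyl for Hydroxy on a Piperidine Side Chain

The compounds below may be only part of what the source reports. "The series", "measured", "known", "first", "only" and "open" are said of these compounds alone.

Compound 1, `O=C(c1ccccc1Cl)N1N=C(c2cc3ccccc3oc2=O)CC1c1ccccc1`: 6640 nM
Compound 2, `CC(C)CNCC(=O)N1N=C(c2cc3ccccc3oc2=O)CC1c1ccccc1`: 29700 nM
Compound 3, `O=C(CN1CCC(O)CC1)N1N=C(c2cc3ccccc3oc2=O)CC1c1ccccc1`: "not active" (no number reported)
Compound 4, `NC(=O)C1CCN(CC(=O)N2N=C(c3cc4ccccc4oc3=O)CC2c2ccccc2)CC1`: to be measured

Of the compounds shown here, three sharing one core have been tested in a functional assay on MGC-803 cells (Homo sapiens) for cytotoxicity, read by MTT assay, with a stated time of 48 h; on this read-out higher numbers stand for weaker inhibition and lower numbers for stronger inhibition. For the measured compounds named here, compound 1 gives 6640 nM, while compound 2, which carries a different group on the carbonyl carbon, gives 29700 nM; the step of a 4.5-fold higher number from compound 1 to compound 2 (0.65 log units; beyond the scatter) is the only measured step in hand. Compound 3 was reported as "not active" (no number reported) in this assay, so no number places it on the scale and it cannot be ranked against compounds 1 and 2.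

Compound 4 differs from compound 3 by carbamoyl in place of hydroxy on a saturated ring carbon. Going by the values given here, no measured step bears on this change: the step from compound 1 to compound 2 alters the group on the carbonyl carbon, not the piperidine ring, and so says nothing about the size or direction of the present change. What is known is that compound 3, the closest relative of compound 4, gave no number at all in this assay. The expectation is therefore that compound 4 remains weak, with a considerable chance that again only a limit is reported. If a number is obtained, compound 4 is estimated at 50000 nM, in the range 15000 nM to 150000 nM.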

Compound 4, half-maximal inhibitory concentration: 21500 nM
The estimate for compound 4 lay 2.3-fold (0.37 log units) above the measured number; low and high end bracket the measured number.
By their numbers in this assay, from the lowest: compound 1; then compounds 4 and 2 (each within the scatter of the next).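

Compound 3 carries hydroxy on the saturated ring carbon and gave no number in this assay, whereas compound 4, with carbamoyl there, gives 21500 nM. This shows that a piperidine side chain on the shared core can give a reading and that this one change at this position separates a blank from a measured value, although the size of that change cannot be read. The 4-carbamoylpiperidin-1-yl group also performs on a level with isobutylamino on the same chain carbon (a 1.4-fold lower number from compound 2 to compound 4 (0.14 log units; within the scatter)), yet replacing 2-chlorophenyl on the carbonyl carbon with the full (4-carbamoylpiperidin-1-yl)methyl group still costs potency (a 3.2-fold higher number from compound 1 to compound 4 (0.51 log units; beyond the scatter)), and no outside measurement is available to account for any of these results.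

The compounds shown leave open whether a carboxylic acid, a primary amine or a methyl ester on the same ring carbon would also give a number, and whether any of these would match compound 1. They also leave open whether a longer chain between that ring carbon and the carbamoyl would shift the reading beyond the usual scatter.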